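This account rests on a few compounds, and the source may have more. Where it says the series, first, only, none or still open, it means among the compounds named here.

In a physicochemical assay for solubility, in phosphate buffer, with a stated time of 2 h, at pH 7.4 (on this read-out lower numbers stand for lower solubility and higher numbers for higher solubility), compound 1 `COc1ccc(Nc2nc(-c3ccccn3)cs2)cc1` gives 80000 nM and compound 2 `COc1ccc(Nc2nc(-c3ccncc3)cs2)cc1` gives 10000 nM as the lower of these two numbers. Going by the values given here, the one measured step between them is an 8.0-fold lower number from compound 1 to compound 2 (0.90 log units; beyond the scatter) with pyridin-4-yl in place of pyridin-2-yl on an aromatic carbon. Compound 3 `COc1ccc(Nc2nc(-c3ncccn3)cs2)cc1` has yet to be measured, and it has pyrimidin-2-yl in place of pyridin-4-yl on an aromatic carbon next to the ring nitrogen (pyrimidin-2-yl in place of pyridin-4-yl on an aromatic carbon). By name, pyrimidin-2-yl looks closer to the pyridin-2-yl of compound 1 at 80000 nM than to the pyridin-4-yl of compound 2, so part of that measured step is expected to be undone, although this rests on a single pair. In this assay the expected step is therefore a 4.0-fold higher number from compound 2 to compound 3 (0.60 log units; beyond the scatter) as an estimate, opposite in direction to the measured step. For compound 3 the estimated value is 40000 nM with an expected range from 12000 nM to 100000 nM for now.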

Compound 3, solubility: 40000 nM
Compound 3: middle estimate and measured number agree at the digits printed; low and high end bracket the measured number.
By their numbers in this assay, from the lowest: compound 2; then compounds 3 and 1 (each within the scatter of the next).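

In this assay, pyrimidin-2-yl in place of pyridin-4-yl gives a 4.0-fold higher number from compound 2 to compound 3 (0.60 log units; beyond the scatter) and so shows that the number of compound 2 is not shared by every six-membered aromatic ring placed at this position. Pyrimidin-2-yl in place of pyridin-2-yl gives a 2.0-fold lower number from compound 1 to compound 3 (0.30 log units; within the scatter) and so leaves these two groups indistinguishable here, even though their rings differ in hetero atom count, while pyridin-4-yl stands apart from both. Nothing measured here explains why these groups differ or match.

The compounds shown leave open how a plain phenyl ring, with no ring nitrogen, would compare at this place. They also leave open what a non-aromatic group there, such as an amine or a carboxylic acid, would do to the number.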